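Removing the benzyl group from compound 2

The source may hold more compounds than are shown below. What is called first, only, known or untested is meant among the compounds shown, and "the series" means these compounds.

Compound 1 `COC(=O)c1ccc(CN(CCCc2c(N)nc(N)nc2O)c2cc(F)c([N+](=O)[O-])cc2[N+](=O)[O-])cc1`: 3500 nM
Compound 2 `COC(=O)c1ccc(CN(CCCc2c(N)nc(N)nc2O)c2cc(F)c(F)cc2[N+](=O)[O-])cc1`: 53000 nM
Compound 3 `Nc1nc(N)c(CCCN(Cc2ccc(NC(CCC(=O)O)C(=O)O)cc2)c2cc(F)c(F)cc2[N+](=O)[O-])c(O)n1`: > 100000 nM (a limit of the assay)

In a functional assay on CCRF-CEM cells (Homo sapiens) for cytotoxicity, in the presence of a further agent that is not named here (on this read-out higher numbers stand for weaker inhibition and lower numbers for stronger inhibition), compound 2 gives 53000 nM, the higher of the two actual numbers. The nearest number belongs to compound 1, at 3500 nM. Compound 3 gives only a limit, > 100000 nM.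

The open case is compound 4 `Nc1nc(N)c(CCCNc2cc(F)c(F)cc2[N+](=O)[O-])c(O)n1`. The structural change is hydrogen in place of 4-(methoxycarbonyl)benzyl on a nitrogen on an aromatic ring.

Two measured steps offer some guidance. The first, a 15-fold higher number from compound 1 to compound 2 (1.18 log units; beyond the scatter), is large and comes with fluoro in place of nitro on an aromatic carbon, but it leaves the 4-(methoxycarbonyl)benzyl group untouched. The second, an at least 1.8-fold higher number from compound 2 to compound 3 (0.27 log units; that floor lies within the scatter), alters that group by putting (1,3-dicarboxypropyl)amino in place of methoxycarbonyl, and its floor lies within the scatter. Within the data shown here, no measured compound lacks the whole group, so this forecast is uncertain.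

Resting on that second step, the expected change is a 1.5-fold higher number from compound 2 to compound 4 (0.18 log units; within the scatter), which means no clear shift beyond the scatter and a slight lean towards a higher number. The estimate for compound 4 is 80000 nM, with an expected range from 25000 nM to 250000 nM.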

Compound 4, half-maximal inhibitory concentration: 97000 nM
Compound 4: the middle estimate sits 1.2-fold (0.08 log units) below what was measured, and the stated range covers the measured number.
By their numbers in this assay, from the lowest: compound 1; then compounds 2 and 4 (each within the scatter of the next). At a limit, above all of these: compound 3.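

In this assay, among these compounds, the earlier steps changed a ring substituent or only the end of the 4-(methoxycarbonyl)benzyl group, whereas compound 4 has lost that whole group from the nitrogen, giving a 1.8-fold higher number from compound 2 to compound 4 (0.26 log units; within the scatter). Taking away all 11 heavy atoms, including a six-membered aromatic ring of carbon only, therefore produces no change that can be told apart from the scatter, so with this difluoro-nitro ring the group adds nothing measurable to the modest effect seen for compound 2. The other member of the series with a changed form of the group, compound 3, cannot be set against compound 4 on a number, as its value is only a limit: the limit of > 100000 nM in this assay, at which 1 of the 4 values shown sits.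

What remains open is whether the same indifference holds in the dinitro setting of compound 1, the only compound here that stands beyond the scatter from compound 2, since no compound shown pairs that ring with hydrogen on the nitrogen. From the compounds shown here alone, it is also open whether a small group on that nitrogen, such as a methyl or a short chain ending in a carboxylic acid, would behave like hydrogen.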